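The source may hold more compounds than are shown below. What is called first, only, known or untested is meant among the compounds shown, and "the series" means these compounds.

The series shares a core bearing a ketone-linked chain and a substituted oxazole, and its members are compared in an assay for inhibition of Fatty-acid amide hydrolase 1 (Rattus norvegicus); a higher number here means a weaker inhibitor, a lower number a stronger inhibitor. Compound 1 `COC(=O)c1ccc(-c2cnc(C(=O)CCc3ccc(-c4ccccc4)cc3)o2)nc1` gives 2.2 nM in this assay. Compound 2 `O=C(O)c1cc(-c2cnc(C(=O)CCc3ccc(-c4ccccc4)cc3)o2)ccn1` gives 50 nM, and compound 3 `N#Cc1cccc(-c2cnc(C(=O)CCc3ccc(COc4ccccc4)cc3)o2)n1` gives 0.56 nM. Among these three numbers compound 2 stands highest: compound 1 lies nearest, and compound 3, which also carries a different tail, lies furthest.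

Going by the values given here, the one step between compounds that differ in a single place is a 23-fold higher number from compound 1 to compound 2 (1.36 log units; beyond the scatter), a large change that came from exchanging the aromatic group on the oxazole. Compound 4 `CS(=O)(=O)c1cnc(C(=O)CCc2ccc(-c3ccccc3)cc2)o1` departs from compound 2 at the same position, but more drastically: methylsulfonyl in place of 2-carboxypyridin-4-yl on an aromatic carbon. The group that enters has no ring and no hydrogen-bond donor, and it sits on the aromatic carbon of the five-membered ring next to the ring oxygen. Among the compounds with values here, no measured pair shows a swap of an aromatic group for a methylsulfonyl, so the step from compound 1 to compound 2 is the only guide, and it shows that this site is sensitive. Compound 2 carries the only free acid in the set. He therefore expects the number for compound 4 to be reported as 20 nM, within 4 nM to 120 nM, a step of a 2.5-fold lower number from compound 2 to compound 4 (0.40 log units; beyond the scatter).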

Compound 4, inhibition constant: 1.2 nM
For compound 4 the middle estimate is 17-fold (1.22 log units) above the measured one, outside the stated range (below it).
By their numbers in this assay, from the lowest: compound 3; then compounds 4 and 1 (each within the scatter of the next); then compound 2.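

In this assay, going by these compounds alone, the aromatic carbon next to the ring oxygen proves able to carry a group with no ring at all: methylsulfonyl, with 4 heavy atoms against the 9 of 2-carboxypyridin-4-yl, brings a 42-fold lower number from compound 2 to compound 4 (1.62 log units; beyond the scatter), a large step that runs opposite to the one the earlier pair showed at this site. Set against 5-(methoxycarbonyl)pyridin-2-yl, the same group gives a 1.8-fold lower number from compound 1 to compound 4 (0.26 log units; within the scatter), so the two groups cannot be told apart here, and a six-membered aromatic ring at this position is shown not to be needed for a low number, with compound 2 alone standing apart among the three compounds sharing this tail. Nothing available here accounts for why these three groups rank as they do.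

Still open, from the compounds shown here alone, is whether the high number of compound 2 goes with its carboxylic acid or with the way its ring is attached, which a methyl ester in place of that acid would help to separate. Also open, going by these compounds, is how a sulfonamide or a plain methyl would read at this position, and whether methylsulfonyl holds its number with the phenoxymethyl-bearing tail of compound 3.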